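Swapping 2-fluoroethoxy for butoxy in compound 2

A few compounds are considered here, and "the series" means these few. Any claim that something is new, unique, unknown or untested is made for them only; others in the source may bear on it.

In a functional assay on HCT-116 cells (Homo sapiens) for cytotoxicity, read by MTT assay, with a stated time of 48 h, in the presence of a further agent that is not named here (a higher number here means that more compound is needed for the effect, a lower number that less compound is needed), compound 1 (`Cn1ncc2c(-c3ccc(F)cc3)cc(NNC(=O)Nc3cc(Cl)cc(Cl)c3)nc21`) gives 39100 nM and compound 2 (`Cn1ncc2c(-c3ccc(F)cc3)cc(NNC(=O)Nc3cc(Cl)nc(OCCF)c3)nc21`) gives 37200 nM while compound 3 (`Cn1ncc2c(-c3ccc(F)cc3)cc(NNC(=O)Nc3cc(F)cc(F)c3)nc21`) gives 46200 nM on the same core. Compound 2 therefore stands level with the other two, since its value cannot be told apart from theirs.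

Compound 4 (`CCCCOc1cc(NC(=O)NNc2cc(-c3ccc(F)cc3)c3cnn(C)c3n2)cc(Cl)n1`) has not been measured. It differs from compound 2 in one place (ethyl in place of fluoro on a saturated chain carbon, two bonds along the chain from an oxygen on an aromatic ring) so that 2-fluoroethoxy becomes butoxy: ethyl in place of fluoro on a saturated chain carbon, two bonds along the chain from an oxygen on an aromatic ring.

For the measured compounds named here, no measured step makes this exact swap. Closest comes a 1.1-fold lower number from compound 1 to compound 2 (0.02 log units; within the scatter) with the 2-fluoroethoxy group arriving as part of a whole new ring group. Two further ring-group swaps give a 1.2-fold higher number from compound 1 to compound 3 (0.07 log units; within the scatter) and a 1.2-fold higher number from compound 2 to compound 3 (0.09 log units; within the scatter) and all three steps lie within the scatter. None of them tests the length of this chain, so they guide only loosely, and no step beyond the scatter is expected in this assay here. An estimated 1.1-fold lower number from compound 2 to compound 4 (0.03 log units; within the scatter) is expected, which stays within the scatter. Compound 4 is expected at 35000 nM with 16000 nM to 62000 nM as the estimated range.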

Compound 4, half-maximal effective concentration: 49400 nM
Beside the measured number, compound 4's estimate is 1.4-fold (0.15 log units) below it, within the range that was stated.
By their numbers in this assay, from the lowest: compounds 2, 1, 3 and 4 (each within the scatter of the next).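

In this assay, the change to butoxy gives a 1.3-fold higher number from compound 2 to compound 4 (0.12 log units; within the scatter), so compound 2 and compound 4 cannot be told apart. This is the first step shown that alters only the chain on the oxygen and leaves the rest of the ring group in place, whereas the earlier steps exchanged whole ring groups and so could not separate the chain from everything else that changed. It shows that, in this assay, removing the fluoro and placing an ethyl on this saturated chain carbon, which takes 2-fluoroethoxy to butoxy, does not move the number beyond the usual scatter; nothing shown bears on why the reading falls where it does.

The compounds shown leave open whether a chain ending in an amine or a carboxylic acid at this place, or a chain longer than butoxy, would give a step beyond the scatter. For the compounds shown here, they also leave open whether a shorter group such as methoxy would read the same, so the single step here marks out only a small part of what this position can hold.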